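The source may hold more compounds than are shown below. What is called first, only, known or untested is meant among the compounds shown, and "the series" means these compounds.

Among the measured compounds shown here, compound 2 `O=[N+]([O-])c1cccc(CSc2nnc(-c3ccc4c(c3)OCCO4)n2-c2ccccc2)c1` gives 45200 nM in a functional assay on HeLa cells (Homo sapiens) for antiproliferative activity, read by MTT assay, with a stated time of 24 h (on this read-out higher numbers stand for weaker inhibition and lower numbers for stronger inhibition), the second highest of the three numbers measured so far. Compound 1 `Sc1nnc(-c2ccc3c(c2)OCCO3)n1-c1ccccc1` gives 51900 nM, and the step of a 1.1-fold lower number from compound 1 to compound 2 (0.06 log units; within the scatter) stays within the scatter. Compound 3 `Fc1ccc(CSc2nnc(-c3ccc4c(c3)OCCO4)n2-c2ccccc2)c(F)c1` gives 18600 nM; the step of a 2.4-fold lower number from compound 2 to compound 3 (0.39 log units; beyond the scatter) is modest but beyond the scatter, as is a 2.8-fold lower number from compound 1 to compound 3 (0.45 log units; beyond the scatter). Compound 4 `Fc1cccc(F)c1CSc1nnc(-c2ccc3c(c2)OCCO3)n1-c1ccccc1` differs from compound 2 by 2,6-difluorophenyl in place of 3-nitrophenyl on a saturated chain carbon bound to a sulfur. For the measured compounds named here, the only measured step that bears on this change is the one in which a 2,4-difluorophenyl replaced the 3-nitrophenyl on the same carbon, and it lowered the number modestly. A similar modest lowering is therefore expected, a 2.3-fold lower number from compound 2 to compound 4 (0.35 log units; beyond the scatter). Compound 4 is expected to give about 20000 nM, most likely between 9000 nM and 45000 nM.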

Compound 4, half-maximal inhibitory concentration: 35200 nM
Beside the measured number, compound 4's estimate is 1.8-fold (0.25 log units) below it, within the range that was stated.
By their numbers in this assay, from the lowest: compounds 3, 4, 2 and 1 (each within the scatter of the next, the first and the last beyond it).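

With 2,6-difluorophenyl on the saturated chain carbon bound to a sulfur, every new step stays within the scatter (a 1.3-fold lower number from compound 2 to compound 4 (0.11 log units; within the scatter); a 1.9-fold higher number from compound 3 to compound 4 (0.28 log units; within the scatter); a 1.5-fold lower number from compound 1 to compound 4 (0.17 log units; within the scatter)). So in this assay, the modest difference that separated compound 3 from compound 1 does not clearly appear for compound 4, although compound 3 and compound 4 cannot themselves be told apart. No measurement here offers a reason for this. As far as these compounds go, whether an amine or a longer alkyl chain on the sulfur would change the number beyond the scatter remains open.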